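Compound 2 to compound 4: a piperidine swap

The source may hold more compounds than are shown below. What is called first, only, known or untested is meant among the compounds shown, and "the series" means these compounds.

In an ADME assay on Vero cells (Chlorocebus sabaeus) for cytotoxicity, with a stated time of 7 days (on this read-out higher numbers stand for lower toxicity in this test and lower numbers for higher toxicity in this test), compound 2 (`COc1ccc2[nH]c(C(=O)N3CC(=O)N(Cc4ccccc4)[C@@H](CN4CCCCC4)C3)cc2c1`) gives 76900 nM as the highest of the two numbers. Compound 1 (`COc1cccc(CN2C(=O)CN(C(=O)c3cc4cc(OC)ccc4o3)C[C@@H]2CCc2ccccc2)c1`) gives 4500 nM as the nearest number, lower by a gap beyond the scatter. Compound 3 (`COc1cccc(CN2C(=O)CN(C(=O)c3cc4cc(OC)ccc4[nH]3)C[C@@H]2c2ccccc2)c1`) has > 10000 nM as a limit and not a number.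

Compound 4 (`COc1ccc2[nH]c(C(=O)N3CC(=O)N(Cc4ccccc4)[C@@H](N4[C@H](C)CCC[C@@H]4C)C3)cc2c1`) differs from compound 2 on a saturated ring carbon: 2,6-dimethylpiperidin-1-yl in place of (piperidin-1-yl)methyl on a saturated ring carbon with 2,6-dimethylpiperidin-1-yl in place of (piperidin-1-yl)methyl. For the measured compounds named here, no measured step covers this change. Compound 2 at 76900 nM is the top number, so any move is expected to go downward. The expected step is a 2.2-fold lower number from compound 2 to compound 4 (0.34 log units; beyond the scatter) in this assay and would lie close to the scatter. For compound 4 the estimate is 35000 nM within a range of 9000 nM to 100000 nM as expected bounds.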

Compound 4, half-maximal cytotoxic concentration: 1400 nM
Estimate against measurement, compound 4: 25-fold (1.40 log units) above; measured number outside the range, below it.
By their numbers in this assay, from the lowest: compound 4; then compound 1; then compound 2.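

In this assay, 2,6-dimethylpiperidin-1-yl in place of (piperidin-1-yl)methyl on a saturated ring carbon gives a 55-fold lower number from compound 2 to compound 4 (1.74 log units; beyond the scatter), so this position is sensitive to what it carries. Both groups hold a six-membered non-aromatic ring with 1 hetero atom, yet the step is large. Compound 3 cannot be placed against this step, as its value is a limit: the limit of > 10000 nM in this assay, at which 1 of the 4 values shown sits.

The single step joins two changes, loss of the methyl link and gain of two ring methyl groups, and the compounds shown do not separate them. Plain piperidin-1-yl on the same carbon would be the direct test.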